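The source may hold more compounds than are shown below. What is called first, only, known or untested is meant among the compounds shown, and "the series" means these compounds.

In a functional assay on B16 cells (Mus musculus) for cytotoxicity, read by CCK-8 assay, with a stated time of 24 h (on this read-out lower numbers stand for stronger inhibition and higher numbers for weaker inhibition), compound 1 (`COc1ccccc1Oc1c(N)nc(-c2ccccc2)nc1Cl`) gives 4610 nM and compound 2 (`COc1ccc(-c2nc(N)c(Oc3ccccc3OC)c(Cl)n2)cc1`) gives 47800 nM as the higher of the two numbers. Compound 3 (`COc1ccccc1Oc1c(N)nc(-c2cccc(Cl)c2)nc1Cl`) carries 3-chlorophenyl in place of 4-methoxyphenyl on an aromatic carbon. Within the data shown here, the one measured step bearing on this, a 10-fold higher number from compound 1 to compound 2 (1.02 log units; beyond the scatter) for methoxy in place of hydrogen on an aromatic carbon, is large. Losing that methoxy is expected to recover much of it, though no chloro compound has been measured. A large step to a lower number is therefore expected in this assay, with an estimated 8.0-fold lower number from compound 2 to compound 3 (0.90 log units; beyond the scatter) overall. For compound 3 the estimated value is 6000 nM (range 1500 nM to 24000 nM).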

Compound 3, half-maximal inhibitory concentration: 17900 nM
For compound 3 the middle estimate is 3.0-fold (0.47 log units) below the measured one; the range from low to high includes it.
By their numbers in this assay, from the lowest: compound 1; then compound 3; then compound 2.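

In this assay, 3-chlorophenyl in place of 4-methoxyphenyl gives a 2.7-fold lower number from compound 2 to compound 3 (0.43 log units; beyond the scatter), so the change recovers only part of the loss seen with methoxy. Chloro in place of hydrogen still gives a 3.9-fold higher number from compound 1 to compound 3 (0.59 log units; beyond the scatter), which shows that a second substituent, not methoxy alone, stands above the unsubstituted compound 1 at this position. No measurement on hand accounts for either step.

From the compounds shown here alone, whether the gap between compound 2 and compound 3 follows the group or its place on the aromatic ring remains open. Also open, going by these compounds, is whether fluoro or dimethylamino there would give a number below that of compound 1.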